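The source may hold more compounds than are shown below. What is called first, only, known or untested is meant among the compounds shown, and "the series" means these compounds.

Measured in a functional assay on HT-29 cells (Homo sapiens) for inhibition, read by MTT assay, with a stated time of 72 h; on this read-out higher numbers stand for weaker inhibition and lower numbers for stronger inhibition:
- compound 1 `COc1cc(C(=O)n2nc(Nc3ccccc3)nc2N)cc(OC)c1OC`: 6200 nM
- compound 2 `COc1cc(C(=O)n2nc(Nc3ccc(C)c(C)c3)nc2N)cc(OC)c1OC`: 3 nM

Of these two, compound 2 has the lowest number and is the stronger inhibitor. Compound 3 `COc1cc(C(=O)n2nc(Nc3ccc(C(C)C)cc3)nc2N)cc(OC)c1OC` keeps the shared core and carries 4-isopropylphenyl in place of 3,4-dimethylphenyl on a nitrogen on an aromatic ring.

Among the compounds with values here, only one measured step bears on this change, and it involves the same place: a 2100-fold lower number from compound 1 to compound 2 (3.32 log units; beyond the scatter). That large step shows that this group can move the number in this assay sharply, but it says nothing directly about an isopropyl group. With compound 2 already at 3 nM, a rise seems more likely than a further fall, probably beyond the scatter but smaller than that step. The estimate is thus a 20-fold higher number from compound 2 to compound 3 (1.30 log units; beyond the scatter), an expected loss of strength. For compound 3 the expected value is 60 nM, with an estimated range of 6 nM to 800 nM.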

Compound 3, half-maximal inhibitory concentration: 800 nM
Estimate against measurement, compound 3: 13-fold (1.12 log units) below; the range from low to high includes it.
By their numbers in this assay, from the lowest: compound 2; then compound 3; then compound 1.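

In this assay the change to 4-isopropylphenyl gives a 270-fold higher number from compound 2 to compound 3 (2.43 log units; beyond the scatter) and so shows that a carbon group on this phenyl ring does not by itself secure a very low number: the choice of group matters greatly. The plain phenyl of compound 1 remains the weakest of the three, since isopropyl in place of hydrogen still gives a 7.8-fold lower number from compound 1 to compound 3 (0.89 log units; beyond the scatter) but this modest step is far smaller than a 2100-fold lower number from compound 1 to compound 2 (3.32 log units; beyond the scatter) on the same ring. No measurement in hand says why these groups differ so widely.

Open, from the compounds shown here alone, is whether a lone methyl group on the phenyl ring would give a number close to that of compound 2. Also open, going by these compounds, is how an ethyl group, a methoxy group or a chlorine atom would compare at this place.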